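The compounds below may be only part of what the source reports. "The series", "measured", "known", "first", "only" and "open" are said of these compounds alone.

Compound 2, `O=S(=O)(NCCCNCc1ccc(Cl)cc1)c1cc(C(F)(F)F)cc(C(F)(F)F)c1`, belongs to a small set built around one shared core. In a functional assay on HT-29 cells (Homo sapiens) for inhibition, read by MTT assay, with a stated time of 72 h (a lower number here means a stronger inhibitor of growth, a higher number a weaker inhibitor of growth), compound 2 gives 2800 nM. Its nearest neighbours are compound 1, `O=S(=O)(NCCCCNCc1ccc(Br)cc1)c1cc(C(F)(F)F)cc(C(F)(F)F)c1`, which in this assay gives 1600 nM, and compound 3, `COc1ccc(CNCCCNS(=O)(=O)c2cc(C(F)(F)F)cc(C(F)(F)F)c2)cc1OC`, which gives 2700 nM. The two steps that join them, a 1.8-fold higher number from compound 1 to compound 2 (0.24 log units; within the scatter) and a 1.0-fold lower number from compound 2 to compound 3 (0.02 log units; within the scatter), both lie within the scatter, so the three measured compounds cannot be told apart on the numbers shown.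

Compound 4, `O=S(=O)(NCCCNCc1ccc(-c2ccccc2)cc1)c1cc(C(F)(F)F)cc(C(F)(F)F)c1`, has not yet been measured. It differs from compound 2 in one place: phenyl in place of chloro on an aromatic carbon. Both measured steps concern what sits on the aromatic ring at the far end of the chain from the sulfonamide nitrogen, and neither moved the number beyond the scatter; neither, however, replaces a halogen with a phenyl group, so the new change is only loosely covered. On that basis a step of no more than the scatter is expected, with a 1.1-fold lower number from compound 2 to compound 4 (0.05 log units; within the scatter) the anticipated outcome. Compound 4 is therefore estimated to give 2500 nM in this assay, within a range from 800 nM to 8000 nM.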

Compound 4, concentration for 50% growth inhibition: 2300 nM
For compound 4 the middle estimate is 1.1-fold (0.04 log units) above the measured one; the range from low to high includes it.
By their numbers in this assay, from the lowest: compounds 1, 4, 3 and 2 (each within the scatter of the next).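

At this aromatic carbon, para to a large group, chloro gives way to phenyl, so one heavy atom is replaced by six heavy atoms and a six-membered aromatic ring of carbon only, yet in this assay the result is a 1.2-fold lower number from compound 2 to compound 4 (0.09 log units; within the scatter) and no more. Compound 3 had only shown that 3,4-dimethoxyphenyl can take the place of 4-chlorophenyl within the scatter, whereas compound 4 shows the same for a whole aromatic ring placed directly on this carbon, a far larger change in atom count than the earlier compounds covered at this spot. Nothing in the information given bears on why so large a change leaves the number within the scatter.

What remains open is whether any group on this carbon can move the number beyond the scatter, since everything shown here at this position lies within it, and a carboxylic acid, a dimethylamino group or a nitrile would test this with atoms unlike those of the groups seen so far. Whether a phenyl bearing a further group of its own would behave as the plain phenyl of compound 4 does also remains unsettled.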